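Cinnamamide aryl substituent: removing the butyl group

The source may report more compounds than this note shows. Statements on the series, on what has been measured and on what is new or still open speak of the compounds shown alone.

Compound 1 `CCCc1cc(N)c2cc(NC(=O)/C=C/c3ccc(Br)cc3)ccc2n1` gives 4 nM in an assay on isolated protein for displacement of a labelled ligand from melanin-concentrating hormone receptor 1 (Homo sapiens); on this read-out lower numbers stand for stronger inhibition and higher numbers for weaker inhibition. Among the compounds with values here, compound 2 `CCCCc1ccc(/C=C/C(=O)Nc2ccc3nc(CCC)cc(N)c3c2)cc1` gives 45 nM in this assay, the higher of the two numbers so far; the only step available, an 11-fold higher number from compound 1 to compound 2 (1.05 log units; beyond the scatter), shows that the group on this aromatic carbon shifts the read-out strongly. Compound 3 `CCCc1cc(N)c2cc(NC(=O)/C=C/c3ccccc3)ccc2n1` is not yet measured. It differs from compound 2 by hydrogen in place of butyl on an aromatic carbon. Within the data shown here, no measured step removes a substituent at that position entirely, so the single bearing step is from compound 1 to compound 2, which was large and pointed upward with the bulkier group; it establishes only that the position is sensitive. With the group taken away, the number for compound 3 is expected to fall somewhere between the two measured values, a step of a 3.0-fold lower number from compound 2 to compound 3 (0.48 log units; beyond the scatter) being anticipated. Compound 3 is estimated at 15 nM, within 4 nM to 60 nM.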

Compound 3, half-maximal inhibitory concentration: 1000 nM
Estimate against measurement, compound 3: 67-fold (1.82 log units) below, outside the stated range (above it).
By their numbers in this assay, from the lowest: compound 1; then compound 2; then compound 3.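

Hydrogen in place of butyl gives a 22-fold higher number from compound 2 to compound 3 (1.35 log units; beyond the scatter) in this assay, and hydrogen in place of bromo gives a 250-fold higher number from compound 1 to compound 3 (2.40 log units; beyond the scatter). The earlier pair showed only that two substituents differ at this carbon, para to a large group; these steps show that both bromo and butyl go with far lower numbers than hydrogen, leaving compound 3 the weakest of the three. No measurement shown bears on why hydrogen stands so far from both groups.

As far as these compounds go, the course of the number across other groups at this carbon remains open, including chloro, methoxy, a shorter chain such as ethyl and a longer chain such as hexyl. Also open, from the compounds shown here alone, is whether an amine or a carboxylic acid here would go with a number nearer that of compound 1 or that of compound 3.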